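A few compounds are considered here, and "the series" means these few. Any claim that something is new, unique, unknown or untested is made for them only; others in the source may bear on it.

Values so far in a physicochemical assay for solubility, read by LC-MS, in phosphate buffer, with a stated time of 24 h, at pH 7.4; on this read-out higher numbers stand for higher solubility and lower numbers for lower solubility:
- Compound 1 `Cn1cc(-c2cnc(NCc3c(F)ccc4c3CCO4)c3cn[nH]c(=O)c23)cn1`: 1000 nM
- Compound 2 `Cc1cc(-c2cnc(NCc3c(F)ccc4c3CCO4)c3cn[nH]c(=O)c23)n(C)n1`: 1000 nM
- Compound 3 `CNC(=O)c1ncc(-c2cnc(NCc3c(F)ccc4c3CCO4)c3cn[nH]c(=O)c23)n1C`: not yet measured

Level with compound 1, compound 2 stands at 1000 nM in this assay. The next change is 1-methyl-2-(methylcarbamoyl)-1H-imidazol-5-yl in place of 1,3-dimethyl-1H-pyrazol-5-yl on an aromatic carbon. Among the compounds with values here, one measured step bears on it: no change at the digits printed from compound 1 to compound 2 (within the scatter). That step replaced one five-membered aromatic ring with another and lies within the scatter. Within the data shown here, no measured compound carries the methylcarbamoyl group, so the two values give no direction for this change. The expected move, no change at the digits printed from compound 2 to compound 3 (within the scatter), is therefore none beyond the scatter, with an uncertain outcome. Compound 3 is estimated at 1000 nM, with an expected range of 400 nM to 4000 nM.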

Compound 3, solubility: 5000 nM
Compound 3: the middle estimate sits 5.0-fold (0.70 log units) below what was measured; measured number above the stated range.
By their numbers in this assay, from the lowest: compounds 1 and 2 (each within the scatter of the next); then compound 3.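

In this assay, the substituent on this aromatic carbon can move the read-out beyond the scatter, which the two pyrazoles alone did not show. Replacing 1,3-dimethyl-1H-pyrazol-5-yl with 1-methyl-2-(methylcarbamoyl)-1H-imidazol-5-yl gives (a 5.0-fold higher number from compound 2 to compound 3 (0.70 log units; beyond the scatter)), and the same group replacing 1-methyl-1H-pyrazol-4-yl gives (a 5.0-fold higher number from compound 1 to compound 3 (0.70 log units; beyond the scatter)). Both steps change the ring and add the methylcarbamoyl group together, and nothing available here explains the rise.

The share of the imidazole ring and the share of the methylcarbamoyl group in these steps remain unseparated. Also open, on these data alone, is how a carboxylic acid, a dimethylamide or a basic amine on the same imidazole would read in this assay (this assay).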